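Swapping the Nitrogen Substituent: From Compound 3 to Compound 4

A few compounds are considered here, and "the series" means these few. Any claim that something is new, unique, unknown or untested is made for them only; others in the source may bear on it.

Measured in an ADME assay on microsomes from liver (Canis lupus familiaris) for metabolic stability, read by LC-MS, using NADPH, with a stated time of 10 min, tested at 0.1 uM; a lower number here means slower removal, a higher number faster removal of the compound:
- compound 1 `COc1ccc(F)cc1N1C(=O)CSC1c1cccc(C(=O)NCCCCc2ccccc2)c1`: 1650 mL.min-1.g-1
- compound 2 `Cc1cccc(N2C(=O)CSC2c2cccc(C(=O)NCCCCc3ccccc3)c2)c1`: 749 mL.min-1.g-1
- compound 3 `O=C(NCCCCc1ccccc1)c1cccc(C2SCC(=O)N2c2ccccc2F)c1`: 815 mL.min-1.g-1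

In this assay compound 3 gives 815 mL.min-1.g-1. It cannot be told apart from its nearest neighbour, as a 1.1-fold higher number from compound 2 to compound 3 (0.04 log units; within the scatter) shows. Only the remaining compound stands clear of it, with a 2.0-fold lower number from compound 1 to compound 3 (0.31 log units; beyond the scatter).

The next compound is compound 4 `CC(F)(F)c1cccc(N2C(=O)CSC2c2cccc(C(=O)NCCCCc3ccccc3)c2)c1`. It keeps the shared core and the phenylbutyl amide chain, but gives up the 2-fluorophenyl on the amide-type nitrogen in a ring: a group of 10 heavy atoms (8 carbon, 2 fluorine; one six-membered aromatic ring of carbon only) in place of a group of 7 heavy atoms (6 carbon, 1 fluorine; one six-membered aromatic ring of carbon only), on an amide-type nitrogen in a ring. Going by the values given here, no measured compound carries the entering group, so the evidence is indirect.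

All three measured steps change this same place. Two are modest, a 2.2-fold lower number from compound 1 to compound 2 (0.34 log units; beyond the scatter) and a 2.0-fold lower number from compound 1 to compound 3 (0.31 log units; beyond the scatter), and both leave the 5-fluoro-2-methoxyphenyl group. The third, a 1.1-fold higher number from compound 2 to compound 3 (0.04 log units; within the scatter), stays within the scatter and is the closest guide, since it links two groups without a methoxy substituent. A step beyond the scatter is therefore not expected in this assay, though a slight rise would not surprise. The expected change is a 1.2-fold higher number from compound 3 to compound 4 (0.07 log units; within the scatter). For compound 4 the estimated value is 950 mL.min-1.g-1, with an expected range of 500 mL.min-1.g-1 to 1800 mL.min-1.g-1.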

Compound 4, intrinsic clearance in microsomes: 912 mL.min-1.g-1
Estimate against measurement, compound 4: 1.0-fold (0.02 log units) above; low and high end bracket the measured number.
By their numbers in this assay, from the lowest: compounds 2, 3, 4 and 1 (each within the scatter of the next, the first and the last beyond it).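

In this assay, putting 1,1-difluoroethyl in place of methyl on an aromatic carbon gives a 1.2-fold higher number from compound 2 to compound 4 (0.09 log units; within the scatter), so this exchange, the first here to bring a group of 10 heavy atoms to the amide-type nitrogen in a ring, does not separate compound 4 from compound 2. The comparison with the 2-fluorophenyl group reads the same way, with a 1.1-fold higher number from compound 3 to compound 4 (0.05 log units; within the scatter), so compounds 2, 3 and 4 cannot be told apart in this assay even though the group on this nitrogen now differs considerably in size. The earlier compounds shown here suggested that the 5-fluoro-2-methoxyphenyl group stood clear of the groups without a methoxy substituent, but a 1.8-fold lower number from compound 1 to compound 4 (0.26 log units; within the scatter) does not reach beyond the scatter, so that separation holds for compounds 2 and 3 and not for compound 4.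

Still open, going by these compounds, is whether a trifluoromethyl group, a nitrile or an amine on this phenyl ring would stay in the same range, and whether a shorter chain in place of the phenylbutyl amide chain, which all four compounds share, would move the number more than any change seen at this nitrogen. The data shown offer no explanation for any of these numbers.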